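A few compounds are considered here, and "the series" means these few. Any claim that something is new, unique, unknown or untested is made for them only; others in the source may bear on it.

In an ADME assay on MT4 cells (Homo sapiens) for cytotoxicity, read by MTT assay, with a stated time of 4 days (a higher number here means that more compound is tolerated, a lower number that less compound is tolerated), compound 1 `CCCNc1nc(C(C)c2c(F)cccc2F)c(C)c(=O)[nH]1` gives 35000 nM. Compound 2 `CCCN(C)c1nc(Cc2c(F)cccc2F)cc(=O)[nH]1` gives 85000 nM, the higher of the two exact numbers, and its gap to compound 1 lies beyond the usual scatter. Compound 3 `O=c1cc(Cc2c(F)cccc2N2CCCC2)nc(N2CCCC2)[nH]1`, which also carries a ring at this place, gives > 73000 nM, a limit of this assay and not a number. Compound 4 `CC1CCN(c2nc(Cc3c(F)cccc3F)cc(=O)[nH]2)CC1` has 4-methylpiperidin-1-yl in place of methyl(propyl)amino on an aromatic carbon of the core of compound 2: 4-methylpiperidin-1-yl in place of methyl(propyl)amino on an aromatic carbon. Going by the values given here, no measured pair isolates this change, so only a slight shift to a lower number is expected in this assay, with the expected step, a 1.4-fold lower number from compound 2 to compound 4 (0.15 log units; within the scatter), staying within the scatter. For compound 4 the estimate is 60000 nM, with an expected range of 22000 nM to 130000 nM.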

Compound 4, half-maximal cytotoxic concentration: > 78000 nM
Compound 4 gave a limit, no number; the forecaster's own chance of this, stated with the estimate: 35%; at least 1.3-fold (0.11 log units) between middle value and limit.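

Compound 4 gives a limit and not a number, and the step from compound 2 to compound 4 cannot be read. The compounds shown leave open how far, and in which direction, 4-methylpiperidin-1-yl in place of methyl(propyl)amino shifts the tolerated concentration.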